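Two aryl ethers, similar cytotoxicity, and a third to estimate

A few compounds are considered here, and "the series" means these few. Any claim that something is new, unique, unknown or untested is made for them only; others in the source may bear on it.

Compound 1 `N#Cc1ccc(Nc2nc(Oc3ccc(Cl)cc3)c3ccccc3n2)cc1` and compound 2 `Cc1cc(Br)cc(Br)c1Oc1nc(Nc2ccc(C#N)cc2)nc2ccccc12` share one core and differ only in the group attached to an oxygen on an aromatic ring. In an ADME assay on MT4 cells (Homo sapiens) for cytotoxicity, read by MTT assay, with a stated time of 4 days (on this read-out lower numbers stand for higher toxicity in this test and higher numbers for lower toxicity in this test), compound 1 gives 198000 nM, and compound 2 gives 150000 nM. The step of a 1.3-fold lower number from compound 1 to compound 2 (0.12 log units; within the scatter) shows that exchanging 4-chlorophenyl for 2,4-dibromo-6-methylphenyl at that oxygen left the read-out essentially unchanged. Compound 2 thus holds the lowest of the two numbers in this assay, but its neighbour compound 1 sits within the scatter, so no order between them can be claimed.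

Compound 3 `Cc1cc(C#N)cc(C)c1Oc1nc(Nc2ccc(C#N)cc2)nc2ccccc12` is not yet measured. Its change from compound 2 is 4-cyano-2,6-dimethylphenyl in place of 2,4-dibromo-6-methylphenyl on an oxygen on an aromatic ring. For the measured compounds named here, the only step that bears on this change is the one from compound 1 to compound 2, where a different aryl group at the same oxygen made no difference beyond the scatter. On that basis the step of a 1.1-fold higher number from compound 2 to compound 3 (0.05 log units; within the scatter) is expected to be small, with no direction that could be trusted. Compound 3 is therefore estimated at 170000 nM in this assay, with a plausible range from 60000 nM to 400000 nM.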

Compound 3, half-maximal cytotoxic concentration: 203000 nM
Compound 3: middle estimate off by 1.2-fold (0.08 log units), on the low side; the measured number falls inside the stated range.
By their numbers in this assay, from the lowest: compounds 2, 1 and 3 (each within the scatter of the next).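

Compound 3 brings in a nitrile on the ring at this oxygen and has no bromine, yet in this assay this exchange gives a 1.4-fold higher number from compound 2 to compound 3 (0.13 log units; within the scatter) and, measured against the 4-chlorophenyl group, gives a 1.0-fold higher number from compound 1 to compound 3 (0.01 log units; within the scatter). The earlier pair had compared only halogen-bearing rings, whereas this result adds a group with a hydrogen-bond acceptor, which neither of the groups before it has, and all three numbers still lie within the scatter of one another. So, across these three compounds, this position tolerates quite different groups on the phenyl ring without a readable difference in this cell test, and no data here offer an explanation for that.

From the compounds shown here alone, all three compounds keep a phenyl ring on the oxygen, so it remains open whether a ring bearing an amine or a carboxylic acid, or a longer alkyl chain in place of the ring, would also fall within the scatter of these numbers. The rest of the molecule is identical in all three, so these results say nothing about changes elsewhere on the shared core.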